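The compounds below may be only part of what the source reports. "The series", "measured", "known", "first", "only" and "open" are said of these compounds alone.

Working notes on the series. Among the measured compounds shown here, compound 1 (`CN1CCN(c2ccc(-c3cc4c(N5CCN(C(=O)Nc6ccccc6F)CC5)ncnc4s3)cc2)CC1`) gives 10300 nM in a functional assay on MDA-MB-231 cells (Homo sapiens) for antiproliferative activity, read by MTT assay, with a stated time of 48 h (a lower number here means a stronger inhibitor, a higher number a weaker inhibitor), while compound 2 (`CN1CCN(c2ccc(-c3cc4c(N5CCN(C(=O)Nc6ccc(Cl)c(C(F)(F)F)c6)CC5)ncnc4s3)cc2)CC1`) gives 2220 nM and so holds the lower of the only two numbers so far. Compound 3 (`CC(C)c1cccc(C(C)C)c1NC(=O)N1CCN(c2ncnc3sc(-c4ccc(N5CCN(C)CC5)cc4)cc23)CC1`) is not yet measured. It carries 2,6-diisopropylphenyl in place of 4-chloro-3-(trifluoromethyl)phenyl on an amide-type nitrogen is the counted change. For the measured compounds named here, one measured step bears on this place: a 4.6-fold lower number from compound 1 to compound 2 (0.67 log units; beyond the scatter) is modest and lies beyond the scatter. Going by the values given here, only two groups have been measured here, and the data hold no group close to the entering one. A step of like size or smaller is expected in this assay toward a higher number, because compound 2 at 2220 nM is the lower of just two values. The estimated move is a 2.3-fold higher number from compound 2 to compound 3 (0.35 log units; beyond the scatter) and remains an expectation only. Compound 3 is expected near 5000 nM with an estimated range from 1500 nM to 16000 nM in this assay read-out.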

Compound 3, half-maximal inhibitory concentration: 8430 nM
Compound 3: the middle estimate sits 1.7-fold (0.23 log units) below what was measured; measured number inside the range.
By their numbers in this assay, from the lowest: compound 2; then compounds 3 and 1 (each within the scatter of the next).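

At the amide-type nitrogen, 2,6-diisopropylphenyl in place of 4-chloro-3-(trifluoromethyl)phenyl gives a 3.8-fold higher number from compound 2 to compound 3 (0.58 log units; beyond the scatter) in this assay, so compound 2 keeps the lowest number of the three and the earlier gain does not carry over to this second replacement. Set against 2-fluorophenyl, the same group gives a 1.2-fold lower number from compound 1 to compound 3 (0.09 log units; within the scatter), so these two groups cannot be told apart in this read-out despite their different substitution, and only 4-chloro-3-(trifluoromethyl)phenyl stands apart so far. No measurement at hand accounts for the difference between these groups.

The compounds shown leave open whether the lower number of compound 2 follows the chlorine or the trifluoromethyl group, as these occur only together here, so a phenyl carrying either one alone would separate them. Also open, as far as these compounds go, is how a cyclohexyl group or a pyridyl ring would read at this place.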